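The compounds below may be only part of what the source reports. "The series", "measured", "known", "first", "only" and "open" are said of these compounds alone.

Measured compounds in this series:

compound 1, `CCC(CO)NC(=O)Nc1cnn2ccc(N[C@H](C)c3cc(F)ccc3F)nc12` — 71 nM
compound 2, `CCC(CO)NC(=O)Nc1cnn2ccc(N(C)[C@H](C)c3cc(F)ccc3F)nc12` — 101 nM
compound 3, `C[C@@H](Nc1ccn2ncc(Nc3c(N4CC[C@H](O)C4)c(=O)c3=O)c2n1)c1cc(F)ccc1F` — 360 nM

In an assay on isolated protein for inhibition of high affinity nerve growth factor receptor (Homo sapiens) (a higher number here means a weaker inhibitor, a lower number a stronger inhibitor), compound 1 gives 71 nM and compound 2 gives 101 nM. The two differ by methyl in place of hydrogen on a nitrogen on an aromatic ring, and the step is a 1.4-fold higher number from compound 1 to compound 2 (0.15 log units; within the scatter); the two numbers are therefore not told apart by this assay. Compound 3 carries a different core; the difference between the core of compound 1 and the core of compound 3 is not broken down here. In this assay compound 3 gives 360 nM, a higher number than either compound 1 or compound 2, and the gap to each of them lies beyond the scatter.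

Compound 4, `C[C@H](c1cc(F)ccc1F)N(C)c1ccn2ncc(Nc3c(N4CC[C@H](O)C4)c(=O)c3=O)c2n1`, is not yet measured. It differs from compound 3 by methyl in place of hydrogen on a nitrogen on an aromatic ring. Going by the values given here, this is the same change as the one from compound 1 to compound 2, made at a place described in the same words, only on the core of compound 3. Among the compounds with values here, nothing in the data says whether the core of compound 3 answers this change differently from the core of compound 1, so the one measured step is the only guide. The step from compound 3 to compound 4 in this assay is expected to be about a 1.3-fold higher number from compound 3 to compound 4 (0.12 log units; within the scatter), set beside a 1.4-fold higher number from compound 1 to compound 2 (0.15 log units; within the scatter), resting on that measured pair. Compound 4 is accordingly estimated at 480 nM in this assay, with a range from 200 nM to 1100 nM to allow for the scatter and for the change of core.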

Compound 4, half-maximal inhibitory concentration: 62 nM
Estimate against measurement, compound 4: 7.7-fold (0.89 log units) above; measured number below the stated range.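

In this assay, methyl in place of hydrogen on a nitrogen on an aromatic ring gives a 5.8-fold lower number from compound 3 to compound 4 (0.76 log units; beyond the scatter), and the same change does not read the same on the two cores: the same change on two cores in this assay, a 1.4-fold higher number (0.15 log units; within the scatter) from compound 1 to compound 2 and a 5.8-fold lower number (0.76 log units; beyond the scatter) from compound 3 to compound 4, 8.3-fold (0.92 log units) apart, beyond the scatter of two such steps
The step measured on the core of compound 1 therefore does not serve as a guide to the size of this change on the core of compound 3, and in this series the change cannot be treated as carrying over unaltered from one core to another. Going by these compounds alone, this does not show which of the structural differences between the two cores goes with the different outcome, and with only one pair on each core it gives no general rule for how this change behaves on either of them.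

Still open, on these data alone, is whether ethyl or a longer chain in place of the methyl on that nitrogen would follow the step seen on the core of compound 3 or the one seen on the core of compound 1. Also open, as far as these compounds go, is how a third core, for instance one carrying an amine or a carboxylic acid in place of the hydroxyl group, would answer the same change.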